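This account rests on a few compounds, and the source may have more. Where it says the series, first, only, none or still open, it means among the compounds named here.

Measured compounds:
- `CNc1nc(NCCCN(C)C)c2sc(-c3cccc(C(F)(F)F)c3)cc2n1` compound 1, 180 ug/mL
- `CNc1nc(NCCCN(C)C)c2sc(-c3ccc(C(F)(F)F)cc3Cl)cc2n1` compound 2, > 100 ug/mL

For the measured compounds named here, in a physicochemical assay for solubility, at pH 2 (on this read-out higher numbers stand for higher solubility and lower numbers for lower solubility), compound 1 gives 180 ug/mL, the only plain number in the set. For compound 2 the read-out is a limit of the assay, > 100 ug/mL; see (the limit of > 100 ug/mL in this assay, at which 1 of the 2 values shown sits). Compound 3, `CNc1nc(NCCCN(C)C)c2sc(-c3cccc(C#N)c3)cc2n1`, is not yet measured and differs from compound 1 by cyano in place of trifluoromethyl on an aromatic carbon. Going by the values given here, no measured pair differing in one place is available, so this change has no precedent. The expected step from compound 1 to compound 3 is a 1.4-fold higher number from compound 1 to compound 3 (0.14 log units; within the scatter), a change not beyond the usual scatter. Compound 3 is estimated at 250 ug/mL, with a range from 120 ug/mL to 550 ug/mL.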

Compound 3, solubility: > 100 ug/mL
Compound 3 was reported as a limit; the forecaster's own chance of this, stated with the estimate: 40%; the middle value is on the limit's open side.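

For the compounds shown here, no step between compound 1 and compound 3 can be read in this assay, since the result for compound 3 is a limit: the limit of > 100 ug/mL in this assay, at which 2 of the 3 values shown sit. The compounds shown leave open the size of any change from cyano in place of trifluoromethyl on the aromatic carbon.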